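Methyl on the Fused Core: From Compound 2 to Compound 4

The compounds below may be only part of what the source reports. "The series", "measured", "known", "first", "only" and "open" are said of these compounds alone.

Measured compounds:
Compound 1 `Cc1cc(-c2nc3sc(C)cn3c2/C=N/NC(=N)N)c(C)s1` gives 19100 nM in a functional assay on cells (Cancer cell lines, Homo sapiens) for inhibition; a lower number here means a stronger inhibitor of growth, a higher number a weaker inhibitor of growth.
Compound 2 `N=C(N)N/N=C/c1c(-c2cccs2)nc2sccn12` gives 24500 nM in this assay.
Compound 3 `Cc1cc(-c2nc3sccn3c2/C=N/NC(=N)N)c(C)s1` gives 26900 nM in this assay.

Compound 2 and compound 3 share the fused core and differ in the aryl group, (thiophen-2-yl in place of 2,5-dimethylthiophen-3-yl on an aromatic carbon); the step of a 1.1-fold higher number from compound 2 to compound 3 (0.04 log units; within the scatter) lies within the scatter. Compound 1 differs from compound 3 by methyl in place of hydrogen on an aromatic carbon, a change that gave the step of a 1.4-fold lower number from compound 3 to compound 1 (0.15 log units; within the scatter).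

Compound 4 `Cc1cn2c(/C=N/NC(=N)N)c(-c3cccs3)nc2s1` carries the same change relative to compound 2, (methyl in place of hydrogen on an aromatic carbon), at the same place, so this is the same change. Compound 4 is expected to move from compound 2 by a 1.3-fold lower number from compound 2 to compound 4 (0.11 log units; within the scatter), set beside a 1.4-fold lower number from compound 3 to compound 1 (0.15 log units; within the scatter), because that step stayed within the scatter. Compound 4 is therefore estimated at 19000 nM in this assay, between 9000 nM and 40000 nM.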

Compound 4, concentration for total growth inhibition: 12300 nM
Beside the measured number, compound 4's estimate is 1.5-fold (0.19 log units) above it, within the range that was stated.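

In this assay, methyl in place of hydrogen on an aromatic carbon gave a 2.0-fold lower number from compound 2 to compound 4 (0.30 log units; within the scatter), and the change read alike on the two cores: the same change on two cores in this assay, a 1.4-fold lower number (0.15 log units; within the scatter) from compound 3 to compound 1 and a 2.0-fold lower number (0.30 log units; within the scatter) from compound 2 to compound 4, 1.4-fold (0.15 log units) apart, within the scatter of two such steps. The change of aryl group gave a 1.6-fold lower number from compound 1 to compound 4 (0.19 log units; within the scatter), and it too read alike on the two cores: the same change on two cores in this assay, a 1.1-fold higher number (0.04 log units; within the scatter) from compound 2 to compound 3 and a 1.6-fold higher number (0.19 log units; within the scatter) from compound 4 to compound 1, 1.4-fold (0.15 log units) apart, within the scatter of two such steps. Going by these compounds alone, all of these steps lie within the scatter, so the agreement shows only that neither change differed measurably between these cores; it does not show that either change alters growth inhibition, or that the same would hold on other cores.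

The compounds shown leave open whether an ethyl group, an amine or a carboxylic acid at that aromatic carbon would give a step beyond the scatter. They also leave open how a phenyl ring would compare with the thiophene groups.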